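Swapping the Aryl Group on a Shared Core

The source may hold more compounds than are shown below. What is called first, only, known or untested is meant among the compounds shown, and "the series" means these compounds.

Measured compounds:
compound 1, `Cn1cc(-c2cccc(C(C)(C)O)c2)c2cc(C(=O)NCc3ccc(C(=O)Nc4ccccc4N)cc3)[nH]c2c1=O`: 2200 nM
compound 2, `Cn1cc(-c2cc(C(C)(C)O)ccc2Oc2ccccc2)c2cc(C(=O)NCc3ccc(C(=O)Nc4ccccc4N)cc3)[nH]c2c1=O`: 100 nM

In a functional assay on MV4-11 cells (Homo sapiens) for antiproliferative activity, read by CCK-8 assay, with a stated time of 72 h (on this read-out higher numbers stand for weaker inhibition and lower numbers for stronger inhibition), compound 1 gives 2200 nM, the higher of the two numbers; compound 2 gives 100 nM. For the measured compounds named here, the single measured step, a 22-fold lower number from compound 1 to compound 2 (1.34 log units; beyond the scatter), comes from phenoxy in place of hydrogen on an aromatic carbon, a group added at the edge of the aryl ring while all else stays.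

Compound 3 `COc1ccccc1-c1cn(C)c(=O)c2[nH]c(C(=O)NCc3ccc(C(=O)Nc4ccccc4N)cc3)cc12` differs from compound 1 by 2-methoxyphenyl in place of 3-(1-hydroxy-1-methylethyl)phenyl on an aromatic carbon. This exchanges the whole aryl group rather than adding to it, so the measured step does not bear on it directly; it only shows that the aryl region can move the number strongly. Going by the values given here, with no closer precedent, the expected change is a 1.8-fold lower number from compound 1 to compound 3 (0.26 log units; within the scatter), uncertain in direction. Compound 3 is therefore estimated to give about 1200 nM, with a range from 300 nM to 5000 nM.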

Compound 3, half-maximal inhibitory concentration: 200 nM
Estimate against measurement, compound 3: 6.0-fold (0.78 log units) above; measured number outside the range, below it.
By their numbers in this assay, from the lowest: compounds 2 and 3 (each within the scatter of the next); then compound 1.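

Exchanging the whole aryl group moves the number as strongly as adding to it: 2-methoxyphenyl in place of 3-(1-hydroxy-1-methylethyl)phenyl gives an 11-fold lower number from compound 1 to compound 3 (1.04 log units; beyond the scatter) in this assay. A large drop at this position therefore does not depend on a phenoxy group, since compound 3 carries none. Nothing available explains why this exchange lowers the number.

The exchange removes the 1-hydroxy-1-methylethyl group and brings in the methoxy group in a single step, so the compounds shown leave open which of the two events accounts for the drop, a question that an unsubstituted phenyl group could help to separate. Also open, from the compounds shown here alone, is whether the methoxy group itself matters, or whether a longer chain such as ethoxy or an amine such as dimethylamino would give a similar number.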